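A few compounds are considered here, and "the series" means these few. Any claim that something is new, unique, unknown or untested is made for them only; others in the source may bear on it.

Compound 1 `O=C(Nc1ccc(Sc2nc3ccccc3s2)cc1)c1cc(Br)cc(Br)c1O` was examined in an assay on isolated protein for inhibition of thiosulfate sulfurtransferase (Homo sapiens), with a stated time of 60 min, in the absence of a further agent; on this read-out lower numbers stand for stronger inhibition and higher numbers for weaker inhibition. In this assay compound 1 gives > 100000 nM, which is a limit of the assay and not a number. Compound 2 `O=C(Nc1ccccc1)c1cc(Br)ccc1O` is a smaller relative of compound 1; in this assay compound 2 gives > 100000 nM, again only a limit. Compound 3 `COc1c(Br)cc(Br)cc1C(=O)Nc1ccc(Sc2nc3ccccc3s2)cc1` carries methyl in place of hydrogen on an oxygen on an aromatic ring relative to compound 1; in this assay compound 3 gives > 100000 nM, once more a limit. The step from compound 1 to compound 3 is therefore a step that the two limits leave unreadable from compound 1 to compound 3. Across the whole set there is nothing but (the limit of > 100000 nM in this assay, at which 3 of the 3 values shown sit). Compound 4 `O=C(Nc1ccc(Sc2nc3ccccc3s2)cc1)c1cc(Br)ccc1O` has not yet been measured; it differs from compound 1 by hydrogen in place of bromo on an aromatic carbon. Among the measured compounds shown here, none of the measured steps concerns a bromo group, so nothing measured bears directly on this change, and the series so far shows only its limit. Compound 4 is expected to remain at that limit too, estimated at 150000 nM with a range from 30000 nM to 1000000 nM. The expected step is a step that the limit leaves unreadable from compound 1 to compound 4, amounting to no change the assay would resolve.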

Compound 4, half-maximal inhibitory concentration: > 100000 nM
Compound 4: only a limit was reported; the forecaster's own chance of this, stated with the estimate: 85%; the middle value lies beyond the limit too.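

Among the compounds shown here, compound 1 and compound 4 each stand only at a limit of the assay, so no step between them can be read. The compounds shown leave open whether hydrogen in place of bromo, or any other change among them, alters inhibition at all, with the whole set resting on one limit: the limit of > 100000 nM in this assay, at which 4 of the 4 values shown sit.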